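The source may hold more compounds than are shown below. What is called first, only, known or untested is meant among the compounds shown, and "the series" means these compounds.

Measured so far in a functional assay on L02 cells (Homo sapiens) for inhibition, read by Griess assay, with stated times of 1 h and 24 h; a higher number here means a weaker inhibitor, a lower number a stronger inhibitor:
compound 1 `CCCc1nn(C)c2c(NC3CC3)nc(/C=C/c3ccc[n+]([O-])c3)nc12` — compound 1 gives 580000 nM.
compound 2 `COc1cc(/C=C/c2nc(Nc3ccc(C)cc3)c3sccc3n2)cc(OC)c1OC` — compound 2 gives only a limit, < 40000 nM.

Compound 2 stands at the lower end of the two results shown, and its value is a limit of the assay rather than a number, as the limit of < 40000 nM in this assay, at which 1 of the 2 values shown sits, records. Compound 1 sits far up the scale. Compound 3 `COc1cc(/C=C/c2nc(OCc3ccccc3)c3sccc3n2)cc(OC)c1OC` carries one change against compound 2: benzyloxy in place of (4-methylphenyl)amino on an aromatic carbon. Among the measured compounds shown here, no step between measured compounds is available for this change, so for compound 3 the step is expected to be none beyond the scatter or at most a modest move toward weaker inhibition. Compound 3 is expected near 40000 nM, within 10000 nM to 150000 nM, which implies an estimated step of a number no lower from compound 2 to compound 3 (the limit leaves the size open).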

Compound 3, half-maximal inhibitory concentration: > 1000000 nM
Compound 3: a limit, no number (the forecaster's own chance of this, stated with the estimate: 40%); middle value at least 25-fold (1.39 log units) from the limit.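

In this assay, benzyloxy in place of (4-methylphenyl)amino next to the ring nitrogen gives an at least 25-fold higher number from compound 2 to compound 3 (1.39 log units; beyond the scatter). This position therefore responds strongly to the exchange, although both groups have the same heavy-atom count and a six-membered aromatic ring of carbon only; the nitrogen and its hydrogen-bond donor leave, and an oxygen enters. Compound 3 gives a limit, not a number: the limit of > 1000000 nM in this assay, at which 1 of the 3 values shown sits.

Going by these compounds, the true size of the step stays open, as compound 2 also gives only a limit. The compounds shown do not separate the linking atom from the ring's placement; a benzylamino group here would bear on that.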